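A few compounds are considered here, and "the series" means these few. Any claim that something is new, unique, unknown or untested is made for them only; others in the source may bear on it.

Compound 1 `CCN1CCN(S(=O)(=O)c2ccc(NC(=O)C3C(C(=O)O)[C@H]4CC[C@@H]3O4)cc2)CC1`: 20200 nM
Compound 2 `O=C(Nc1ccc(S(=O)(=O)N2CCOCC2)cc1)C1C(C(=O)O)[C@H]2CC[C@@H]1O2`: 19300 nM

In a functional assay on HepG2 cells (Homo sapiens) for cytotoxicity, read by MTT assay, with a stated time of 48 h (a higher number here means a weaker inhibitor, a lower number a stronger inhibitor), compound 2 cannot be told apart from compound 1. Within the data shown here, the only measured step, a 1.0-fold lower number from compound 1 to compound 2 (0.02 log units; within the scatter), put morpholin-4-yl in place of 4-ethylpiperazin-1-yl on a sulfonyl sulfur, and it stays within the scatter.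

Compound 3 `O=C(Nc1ccc(S(=O)(=O)NC2CC2)cc1)C1C(C(=O)O)[C@H]2CC[C@@H]1O2` carries its change at that same place, with cyclopropylamino in place of morpholin-4-yl on a sulfonyl sulfur. The measured step is the only one that bears on this change, and it is thin evidence, since it covers just one exchange of groups and cyclopropylamino was not part of it. With nothing else to go on, no step beyond the scatter is expected in this assay. The expected step is a 1.0-fold lower number from compound 2 to compound 3 (0.01 log units; within the scatter). For compound 3 the estimated value is 19000 nM, with an expected range of 8000 nM to 45000 nM.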

Compound 3, half-maximal inhibitory concentration: 26200 nM
For compound 3 the middle estimate is 1.4-fold (0.14 log units) below the measured one; the measured number falls inside the stated range.
By their numbers in this assay, from the lowest: compounds 2, 1 and 3 (each within the scatter of the next).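

Among these compounds, with cyclopropylamino, the sulfonyl sulfur in this assay now carries a group with a hydrogen-bond donor and a three-membered ring, where the earlier compounds had neither, yet the exchange for morpholin-4-yl gives a 1.4-fold higher number from compound 2 to compound 3 (0.13 log units; within the scatter) and the exchange for 4-ethylpiperazin-1-yl gives a 1.3-fold higher number from compound 1 to compound 3 (0.11 log units; within the scatter) as well. All three groups on this sulfonyl sulfur therefore give numbers that stay within the scatter of one another, so neither the change in ring size nor the added donor separates these compounds in this assay. Nothing measured here offers an explanation for this result. As far as these compounds go, it remains open whether an unsubstituted amino group or a longer chain such as hexylamino on the same sulfonyl sulfur would give a step beyond the scatter. The compounds shown also leave open whether changes elsewhere on the shared core would do so.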